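The source may report more compounds than this note shows. Statements on the series, on what has been measured and on what is new or still open speak of the compounds shown alone.

Measured compounds:
compound 1 `O=C(Nc1cc(C(F)(F)F)cc(C(F)(F)F)c1)C1CCc2ccccc2N1C(=O)c1cccc(Cl)c1`: 420 nM
compound 2 `O=C(Nc1ccc(C(F)(F)F)cc1)c1ccc2ccccc2n1`: > 90000 nM
compound 3 `O=C(Nc1ccccc1O)C1CCc2ccccc2N1C(=O)c1ccc(Cl)cc1`: 19200 nM

The read-out is a functional assay on NCI-H23 cells (Homo sapiens) for cytotoxicity, read by sulforhodamine B assay, with a stated time of 72 h; a lower number here means a stronger inhibitor of growth, a higher number a weaker inhibitor of growth. Of the two numbers shown there, compound 1 gives the lowest, at 420 nM. The nearest number is that of compound 3, at 19200 nM, a gap that lies beyond the scatter of repeated measurements. Compound 2 gives only a limit of the assay, > 90000 nM, and no number; the limit is the limit of > 90000 nM in this assay, at which 1 of the 3 values shown sits. No two of the measured compounds differ in a single place, so no measured step can be read off between them.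

The next compound, compound 4 `CCCCCCCCC(=O)N1c2ccccc2CCC1C(=O)Nc1cc(C(F)(F)F)cc(C(F)(F)F)c1`, is built from compound 1 by one change: octyl in place of 3-chlorophenyl on a carbonyl carbon. There is no measured step of this kind in the series to set a size against, so the expectation rests on the structures alone. The step of a 6.0-fold higher number from compound 1 to compound 4 (0.77 log units; beyond the scatter) is expected to go toward a higher number, by more than the scatter but not far beyond it. For compound 4 in this assay the estimate is 2500 nM, with a range from 500 nM to 12000 nM.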

Compound 4, concentration for 50% growth inhibition: 3230 nM
For compound 4 the middle estimate is 1.3-fold (0.11 log units) below the measured one; the measured number falls inside the stated range.
By their numbers in this assay, from the lowest: compound 1; then compound 4; then compound 3. At a limit, above all of these: compound 2.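

Among these compounds, this is the first measured step at this position: in this assay octyl in place of 3-chlorophenyl on a carbonyl carbon gives a 7.7-fold higher number from compound 1 to compound 4 (0.89 log units; beyond the scatter) and is rated a modest change. The position therefore accepts a chain with no ring, with growth inhibition weakened but not lost, as compound 4 at 3230 nM still gives a number and not a limit of the assay. Among the compounds shown here, nothing measured bears on why the step goes in this direction, so the single step gives its size and direction but no cause.

The compounds shown do not separate the loss of the ring from the loss of the chlorine, and an unsubstituted phenyl or a cyclohexyl on the same carbonyl would address that. Also open, from the compounds shown here alone, is how the number depends on chain length and chain end, for example with a butyl chain, a dodecyl chain, or an octyl chain ending in an amine or a carboxylic acid.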